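Trimming a Methyl on the Pyrazole Arm of Compound 1

The source may hold more compounds than are shown below. What is called first, only, known or untested is meant among the compounds shown, and "the series" means these compounds.

Compound 1 `Cc1cc(C)n(CCOC2CC(=O)Nc3c2c(C)nn3-c2ncnc3nc[nH]c23)n1`: 16 nM
Compound 2 `Cc1nn(-c2ncnc3nc[nH]c23)c2c1C(OC(=O)c1ccc(F)cc1)CC(=O)N2`: 4 nM
Compound 3 `Cc1nn(-c2ncnc3nc[nH]c23)c2c1C(OCC(C)C)CC(=O)N2`: 4 nM

In a functional assay on HEK293 cells for agonist activity at G-protein coupled receptor 39 (Homo sapiens), read by scintillation proximity assay and inositol phosphate accumulation, with a stated time of 75 min, in the presence of a further agent that is not named here (on this read-out lower numbers stand for an effect already at smaller amounts and higher numbers for an effect only at larger amounts of compound), compound 1 gives the highest of these three numbers. Both other compounds sit lower: a 4.0-fold lower number from compound 1 to compound 2 (0.60 log units; beyond the scatter) and a 4.0-fold lower number from compound 1 to compound 3 (0.60 log units; beyond the scatter), while no change at the digits printed from compound 2 to compound 3 (within the scatter). Compound 4 `Cc1nn(-c2ncnc3nc[nH]c23)c2c1C(OCCn1nccc1C)CC(=O)N2` differs from compound 1 by hydrogen in place of methyl on an aromatic carbon. Among the compounds with values here, no measured step touches this methyl. The two steps away from compound 1 replace the whole 2-(3,5-dimethyl-1H-pyrazol-1-yl)ethyl arm, so they speak only loosely to a small trim within it, and their modest size gives no reason to expect a large move either way. The expected step is therefore one within the scatter, a 1.1-fold lower number from compound 1 to compound 4 (0.06 log units; within the scatter). Compound 4 is estimated at 14 nM, with a range from 5 nM to 40 nM.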

Compound 4, half-maximal effective concentration: 10 nM
Compound 4: middle estimate off by 1.4-fold (0.15 log units), on the high side, and the stated range covers the measured number.
By their numbers in this assay, from the lowest: compounds 2 and 3 (each within the scatter of the next); then compounds 4 and 1 (each within the scatter of the next).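

Swapping this methyl for hydrogen on the aromatic carbon gives a 1.6-fold lower number from compound 1 to compound 4 (0.20 log units; within the scatter), so the 3,5-dimethyl-1H-pyrazol-1-yl group does not depend measurably on that methyl here. The trimmed arm still stands apart from the isobutyl and (4-fluorophenyl)carbonyl groups, with a 2.5-fold higher number from compound 3 to compound 4 (0.40 log units; beyond the scatter) and a 2.5-fold higher number from compound 2 to compound 4 (0.40 log units; beyond the scatter). No supporting data are available to explain any of these steps. As far as these compounds go, it remains open whether the remaining methyl of the 5-methyl-1H-pyrazol-1-yl group can also be removed. From the compounds shown here alone, it is also open how an ethyl group or a chlorine atom on the trimmed carbon would read.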